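This account rests on a few compounds, and the source may have more. Where it says the series, first, only, none or still open, it means among the compounds named here.

Of the compounds shown here, three have been tested in a functional assay on SMMC-7721 cells (Homo sapiens) for cytotoxicity, read by MTT assay, with a stated time of 4 days; on this read-out higher numbers stand for weaker inhibition and lower numbers for stronger inhibition. Compound 2 `C=C1C[C@]23C[C@@]1(O)CC[C@H]2c1ccc(O)c(C)c1[C@@H]3Cn1cc(-c2ccc(F)cc2)nn1` carries a 4-fluorophenyl group. In this assay compound 2 gives > 20000 nM, which is a limit of the assay rather than a number. Compound 1 `C=C1C[C@]23C[C@@]1(O)CC[C@H]2c1ccc(O)c(C)c1[C@@H]3Cn1cc(-c2ccc(C(F)(F)F)cc2)nn1` differs from compound 2 only by trifluoromethyl in place of fluoro on an aromatic carbon. In this assay compound 1 gives > 20000 nM, again a limit. The step that the two limits leave unreadable from compound 2 to compound 1 therefore cannot be read, because the limit of > 20000 nM in this assay, at which 3 of the 3 values shown sit, shows both values sitting at the same limit. Compound 3 `C=C1C[C@]23C[C@@]1(O)CC[C@@H]2c1cccc(C)c1[C@@H]3Cn1cc(-c2ccc(F)cc2)nn1` shares the 4-fluorophenyl group with compound 2, but the difference between the two cores is not broken down here. In this assay compound 3 gives > 20000 nM, once more a limit. Compound 4 `C=C1C[C@]23C[C@@]1(O)CC[C@@H]2c1cccc(C)c1[C@@H]3Cn1cc(-c2ccc(C(F)(F)F)cc2)nn1` stands to compound 3 as compound 1 stands to compound 2: it carries trifluoromethyl in place of fluoro on an aromatic carbon, at a place described in the same words, so this is the same change. Because the step that the two limits leave unreadable from compound 2 to compound 1 left both partners at the limit (the limit of > 20000 nM in this assay, at which 3 of the 3 values shown sit), the step that the limit leaves unreadable from compound 3 to compound 4 is expected to be unreadable as well, with compound 4 most likely reported only as a limit. Compound 4 is estimated at 30000 nM, between 15000 nM and 100000 nM.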

Compound 4, half-maximal inhibitory concentration: > 20000 nM
Compound 4: a limit, no number (the forecaster's own chance of this, stated with the estimate: 85%); the middle value does not contradict the limit.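

No size can be read for the change from compound 3 to compound 4, because both compounds sit at the same limit rather than at a number: the limit of > 20000 nM in this assay, at which 4 of the 4 values shown sit. The compounds shown leave open whether swapping fluoro for trifluoromethyl changes anything in this assay, and what potency any of them has beyond that limit.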